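The source may report more compounds than this note shows. Statements on the series, on what has been measured and on what is new or still open speak of the compounds shown alone.

Series notes. In an assay for inhibition of Tryptophan 2,3-dioxygenase (Homo sapiens), with stated times of 10 min and 60 min, tested at 100 uM (on this read-out higher numbers stand for a stronger effect at the one concentration tested and lower numbers for a weaker effect), compound 3 `FC(F)(F)c1cccc(CNc2cc(C(F)(F)F)cc3[nH]ncc23)c1` gives 74%, the second highest of three numbers. Nearest is compound 2 `O=[N+]([O-])c1cccc(CNc2cc(C(F)(F)F)cc3[nH]ncc23)c1`, which in this assay gives 82%; the step of a number 8 percentage points lower from compound 2 to compound 3 (within the scatter) is within the scatter. Furthest is compound 1 `O=C1NCc2c(NCc3ccccc3[N+](=O)[O-])cccc21`, built on a different core, which gives 29%.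

Compound 4 `Nc1cccc(CNc2cc(C(F)(F)F)cc3[nH]ncc23)c1` is not yet measured. It differs from compound 3 by amino in place of trifluoromethyl on an aromatic carbon. Among the compounds with values here, the only measured step, a number 8 percentage points lower from compound 2 to compound 3 (within the scatter), concerns a different exchange at that same place and was within the scatter, so it offers little direct guidance; there is no measured exchange of trifluoromethyl for amino anywhere in the set. A step of a number 14 percentage points lower from compound 3 to compound 4 (beyond the scatter) is expected, with wide uncertainty. Compound 4 is therefore estimated at 60%, in the range 30% to 85%.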

Compound 4, a percentage reported as inhibition, at one concentration (the size of the read-out at that concentration, not a potency): 89%
For compound 4 the middle estimate is 29 percentage points below the measured one; the whole stated range lies below it.
By their numbers in this assay, from the lowest: compound 1; then compounds 3, 2 and 4 (each within the scatter of the next, the first and the last beyond it).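

Within the data shown here, on the shared core, the place on the carbon-only aromatic ring accepts amino: the exchange for trifluoromethyl gives a number 15 percentage points higher from compound 3 to compound 4 (beyond the scatter) and separates two groups at this position for the first time. The exchange for nitro gives a number 7 percentage points higher from compound 2 to compound 4 (within the scatter) and so does not separate amino from nitro. Nothing available bears on the reason for either step.

Open, from the compounds shown here alone, is whether an acetamide, a methylamino group or a carboxylic acid at this place would keep the read-out of amino. Also open, going by these compounds, is whether amino would act the same way on the core of compound 1.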